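Carbamate in place of ethyl on the shared aryloxy position

The compounds below may be only part of what the source reports. "The series", "measured", "known", "first", "only" and "open" are said of these compounds alone.

Three compounds of the series have been run in a functional assay on PANC-1 cells (Homo sapiens) for inhibition, read by MTT assay, with a stated time of 24 h, tested at 10 uM (on this read-out higher numbers stand for more inhibition at the one concentration tested (going by the name of the read-out) and lower numbers for less inhibition), so far. Compound 1 `CC(C)=CCC1Cc2c(OCCCOc3ccc([N+](=O)[O-])cc3)cc(=O)n(CCCO)c2CC1(C)C` carries a nitrophenoxypropyl chain on the ring oxygen and gives 0% in this assay. Compound 2 `CC(C)=CCC1Cc2c(OC(=O)Nc3ccc(F)cc3)cc(=O)n(CCCO)c2CC1(C)C` carries a (4-fluorophenyl)carbamoyl group on that oxygen and gives 0%. Compound 3 `CCOc1cc(=O)n(CCCO)c2c1CC(C/C=C(\C)CCC=C(C)C)C(C)(C)C2` carries an ethyl group there and a longer side chain on the core, and gives 0.8% in this assay. The three numbers lie within the scatter of one another, so compound 3 does not stand apart from compound 1 or compound 2; none of the three shows inhibition at the single concentration tested.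

Compound 4 `CC(C)=CCC/C(C)=C/CC1Cc2c(OC(=O)Nc3ccc(Cl)c(Cl)c3)cc(=O)n(CCCO)c2CC1(C)C` is not yet measured. The counted change from compound 3 is (3,4-dichlorophenyl)carbamoyl in place of ethyl on an oxygen on an aromatic ring. The closest measured point of comparison for a carbamoyl group on this oxygen is compound 2, which gives 0% in this assay. Going by the values given here, no step between measured compounds is recorded, so no size of effect for any change can be read from the data. On the three flat numbers, the expected step from compound 3 to compound 4 is a number 3.2 percentage points higher from compound 3 to compound 4 (within the scatter), none beyond the scatter. Compound 4 is estimated to give 4% in this assay, within 0% to 20%.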

Compound 4, a percentage reported as inhibition, at one concentration (the size of the read-out at that concentration, not a potency): 0%
Beside the measured number, compound 4's estimate is 4 percentage points above it, and the stated range covers the measured number.
By their numbers in this assay, from the lowest: compounds 1, 2, 4 and 3 (each within the scatter of the next).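

In this assay, going by these compounds alone, (3,4-dichlorophenyl)carbamoyl in place of ethyl on an oxygen on an aromatic ring gives a number 0.8 percentage points lower from compound 3 to compound 4 (within the scatter), the first step between two measured compounds. At this position, then, a change that brings in a six-membered aromatic ring, a hydrogen-bond donor and a hydrogen-bond acceptor leaves the read-out within the scatter at the one concentration tested, although this single step comes from a starting point that already shows essentially no inhibition, so any loss could not be seen. Nothing in the data shown offers an explanation for this flat result.

Going by these compounds, whether any group on this oxygen can raise the number beyond the scatter stays open, for example a primary amine or a carboxylic acid at the end of a longer chain. Also open, on these data alone, is whether replacing the 3-hydroxypropyl group on the ring nitrogen of the shared core with a morpholine-bearing chain would give a reading in this assay clear of the scatter, which any comparison of groups at the aromatic oxygen would need.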